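The source may report more compounds than this note shows. Statements on the series, on what has been measured and on what is new or still open speak of the compounds shown alone.

Compound 1 (`COc1ccc(N2CCN(C(=S)SCc3ccc4nc(N)nc(N)c4c3)CC2)cc1`) gives 1770 nM in a functional assay on HT-29 cells (Homo sapiens) for antiproliferative activity, read by MTT assay, with a stated time of 72 h (a higher number here means a weaker inhibitor, a lower number a stronger inhibitor), and compound 2 (`Nc1nc(N)c2cc(CSC(=S)N3CCN(c4ccc(Cl)c(Cl)c4)CC3)ccc2n1`) gives 3480 nM in the same test, while compound 3 (`Nc1nc(N)c2cc(CSC(=S)N3CCN(c4ccc([N+](=O)[O-])cc4)CC3)ccc2n1`) gives 3320 nM there. Compound 3 thus stands among three values that cannot be told apart. All three compounds share one core and differ only in the group carried on the amine nitrogen in a ring. The steps among them are a 2.0-fold higher number from compound 1 to compound 2 (0.29 log units; within the scatter) and a 1.9-fold higher number from compound 1 to compound 3 (0.27 log units; within the scatter) together with a 1.0-fold lower number from compound 2 to compound 3 (0.02 log units; within the scatter) on the same scale, and each stays inside the usual scatter.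

Compound 4 (`Nc1nc(N)c2cc(CSC(=S)N3CCN(c4ccccn4)CC3)ccc2n1`) brings one further exchange at that place, with pyridin-2-yl in place of 4-nitrophenyl on an amine nitrogen in a ring is the difference from compound 3. Within the data shown here, the three measured steps are the only evidence that bears on this change. Since none of them exceeds the scatter, no step beyond the scatter is expected in this assay and no direction can be named. Among the measured compounds shown here, no measured compound carries pyridin-2-yl, however, so the expected range is kept wide. The estimated change is a 1.2-fold lower number from compound 3 to compound 4 (0.09 log units; within the scatter) and is not expected to be a real one. Compound 4 is estimated at 2700 nM with an expected range from 1200 nM to 6000 nM in this test.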

Compound 4, half-maximal inhibitory concentration: 6200 nM
Compound 4: middle estimate off by 2.3-fold (0.36 log units), on the low side; the whole stated range lies below it.
By their numbers in this assay, from the lowest: compounds 1, 3, 2 and 4 (each within the scatter of the next, the first and the last beyond it).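

Pyridin-2-yl gives the first step at this position that clears the scatter, though only against 4-methoxyphenyl: a 3.5-fold higher number from compound 1 to compound 4 (0.54 log units; beyond the scatter) is a modest change on the amine nitrogen in the ring. Against the other two groups the exchange cannot be told apart from noise, with a 1.9-fold higher number from compound 3 to compound 4 (0.27 log units; within the scatter) and a 1.8-fold higher number from compound 2 to compound 4 (0.25 log units; within the scatter), so pyridin-2-yl is separated from neither 4-nitrophenyl nor 3,4-dichlorophenyl. Among these compounds, the position therefore does respond to the group it carries in this assay, but compounds 2 and 3 lie within the scatter of both ends, and nothing at hand explains the one step that stands out.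

The compounds shown leave open whether the step belongs to the ring nitrogen of pyridin-2-yl or to the loss of the 4-methoxyphenyl group, a question that an unsubstituted phenyl, a pyridin-4-yl or a pyrimidin-2-yl on the same nitrogen would bear on. They also leave open how the position behaves with no aromatic ring on that nitrogen at all, as with a methyl or a longer alkyl chain.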